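Replacing the hexyl chain by an ester on the aryl carbon

This account rests on a few compounds, and the source may have more. Where it says the series, first, only, none or still open, it means among the compounds named here.

Compound 1 `CCc1ccc(NC(=O)N[C@@H](C)c2ccccc2)cc1`, compound 2 `C[C@H](NC(=O)Nc1ccc(C(C)(C)C)cc1)c1ccccc1` and compound 3 `CCCCCCc1ccc(NC(=O)N[C@@H](C)c2ccccc2)cc1` share a common core and differ only in the group carried on one aromatic carbon. In an ADME assay on the whole organism with Oryza sativa as the target, tested at 0.1 uM (on this read-out higher numbers stand for a weaker effect at the one concentration tested and lower numbers for a stronger effect), compound 1 gives 99%, compound 2 gives 100% and compound 3 gives 99%. Compound 3 stands level with compound 1 at the digits shown, the two together being the lowest of the three numbers, and its nearest neighbour is compound 1 while compound 2 is furthest; the step of a number 1 percentage points lower from compound 2 to compound 3 (within the scatter) lies within the scatter, as does the step of a number 1 percentage points higher from compound 1 to compound 2 (within the scatter) and the step of no change at the digits printed from compound 1 to compound 3 (within the scatter). Compound 4 `CCOC(=O)c1ccc(NC(=O)N[C@@H](C)c2ccccc2)cc1` is the next member of the series and differs from compound 3 as ethoxycarbonyl in place of hexyl on an aromatic carbon. For the measured compounds named here, the steps that bear on this change are those that also exchanged the group on that aromatic carbon, and all of them were small and within the scatter, with the whole series sitting close to the top of the scale in this assay. Compound 4 is therefore expected to show no step beyond the scatter, and the estimate for compound 4 is 98%, with a range from 90% to 100%. The expected step of a number 1 percentage points lower from compound 3 to compound 4 (within the scatter) would thus remain within the usual scatter.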

Compound 4, a percentage reported as activity, at one concentration (the size of the read-out at that concentration, not a potency): 99%
For compound 4 the middle estimate is 1 percentage points below the measured one; the range from low to high includes it.
By their numbers in this assay, from the lowest: compounds 1, 3, 4 and 2 (each within the scatter of the next).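

In this assay, ethoxycarbonyl in place of hexyl on this aromatic carbon gives no change at the digits printed from compound 3 to compound 4 (within the scatter) and the exchange read against the other two groups gives a number 1 percentage points lower from compound 2 to compound 4 (within the scatter) and no change at the digits printed from compound 1 to compound 4 (within the scatter) so the ester fits the flat picture seen so far. Compound 1, compound 2 and compound 3 carry only carbon groups at this position, whereas compound 4 brings oxygen, a double bond outside the aromatic rings and hydrogen-bond acceptors there, and this difference in make-up leaves the read-out within the scatter of all three. The position therefore tolerates a group of a different kind without any visible step on this read-out, though nothing measured here speaks to why that is so.

Going by these compounds, whether an amine, a carboxylic acid or a hydroxyl group on this aromatic carbon would give a step beyond the scatter remains open. Also open, on these data alone, is whether any of these four compounds would separate from the others at another concentration, or whether a change elsewhere on the shared core, such as a substituent on the second aromatic ring, would move the read-out at all.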